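A few compounds are considered here, and "the series" means these few. Any claim that something is new, unique, unknown or untested is made for them only; others in the source may bear on it.

Compounds measured so far:
Compound 1 `COc1cc2nc(/C=C/c3cccnc3)nc(N3CCC(CCNS(N)(=O)=O)CC3)c2cc1OC` gives 86%.
Compound 2 `COc1ccccc1/C=C/c1nc(N2CCC(CCNS(N)(=O)=O)CC2)c2cc(OC)c(OC)cc2n1` gives 74%.
Compound 3 `COc1ccc(/C=C/c2nc(N3CCC(CCNS(N)(=O)=O)CC3)c3cc(OC)c(OC)cc3n2)cc1` gives 66%.

In an assay on cells for inhibition of Ectonucleotide pyrophosphatase/phosphodiesterase family member 1 (Homo sapiens), with a stated time of 60 min, tested at 1 uM (on this read-out higher numbers stand for more inhibition at the one concentration tested (going by the name of the read-out) and lower numbers for less inhibition), compound 3 has the lowest of the three numbers. The step of a number 8 percentage points lower from compound 2 to compound 3 (within the scatter) lies within the scatter, so these two cannot be told apart, while the step of a number 20 percentage points lower from compound 1 to compound 3 (beyond the scatter) lies beyond it. Compound 4 `COc1cc2nc(CCc3ccc(F)cc3)nc(N3CCC(CCNS(N)(=O)=O)CC3)c2cc1OC` has not been measured in this assay. It differs from compound 3 in one place: 2-(4-fluorophenyl)ethyl in place of 2-(4-methoxyphenyl)ethenyl on an aromatic carbon. Among the measured compounds shown here, none of the measured steps covers this change. For the measured compounds named here, the steps of a number 12 percentage points lower from compound 1 to compound 2 (beyond the scatter) and a number 20 percentage points lower from compound 1 to compound 3 (beyond the scatter) and a number 8 percentage points lower from compound 2 to compound 3 (within the scatter) all swap the aromatic ring on the double-bonded chain carbon and leave the double bond in place, and no compound shows what removing the double bond or exchanging methoxy for fluorine does. The expectation for compound 4 is therefore wide: a step of about a number 8 percentage points lower from compound 3 to compound 4 (within the scatter) is estimated, within the scatter but with little confidence in either direction. Compound 4 is expected to give about 58%, within a range from 30% to 82%.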

Compound 4, a percentage reported as inhibition, at one concentration (the size of the read-out at that concentration, not a potency): 69%
The estimate for compound 4 lay 11 percentage points below the measured number; measured number inside the range.
By their numbers in this assay, from the lowest: compounds 3, 4 and 2 (each within the scatter of the next); then compound 1.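

In this assay the aromatic carbon between two ring nitrogen atoms accepts 2-(4-fluorophenyl)ethyl in place of 2-(4-methoxyphenyl)ethenyl with no readable change (a number 3 percentage points higher from compound 3 to compound 4 (within the scatter)). The comparison with 2-(2-methoxyphenyl)ethenyl reads the same way (a number 5 percentage points lower from compound 2 to compound 4 (within the scatter)), so a group without the chain double bond and carrying fluorine instead of methoxy cannot be told apart from either methoxy-bearing ethenyl group. Only 2-(pyridin-3-yl)ethenyl stands apart from the new group (a number 17 percentage points lower from compound 1 to compound 4 (beyond the scatter)).

Nothing at hand explains these numbers. The compounds shown leave open what the loss of the double bond and the exchange of methoxy for fluorine each contribute alone, which 2-(4-methoxyphenyl)ethyl and 2-(4-fluorophenyl)ethenyl would separate, and whether 2-(pyridin-3-yl)ethyl would stay level with its ethenyl counterpart.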